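This account rests on a few compounds, and the source may have more. Where it says the series, first, only, none or still open, it means among the compounds named here.

Compound 2 `CC1=CC[C@H](C(C)C)c2cc(C)c(OC(=O)c3ccccc3)cc21` is an ester of the shared core, and in a functional assay on U-251 cells (Homo sapiens) for antiproliferative activity, read by sulforhodamine B assay, with a stated time of 48 h, tested at 50 uM (on this read-out lower numbers stand for less inhibition and higher numbers for more inhibition at the one concentration tested (going by the name of the read-out)), compound 2 gives 25.8%. Among the compounds with values here, the only other measured compound is compound 1 `CC1=CC[C@H](C(C)C)c2cc(C)c(OC(=O)c3ccc([N+](=O)[O-])cc3)cc21`, which carries a nitro group on the ester's aromatic ring; in this assay compound 1 gives 16.8%. Within the data shown here, the one step between them, a number 9 percentage points higher from compound 1 to compound 2 (within the scatter), is within the scatter, so the two measured compounds cannot be told apart on these numbers.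

Compound 3 `CC1=CC[C@H](C(C)C)c2cc(C)c(OC(=O)c3cccc(C(F)(F)F)c3)cc21` differs from compound 2 by trifluoromethyl in place of hydrogen on an aromatic carbon. Among the measured compounds shown here, the single measured step bears on this change only loosely: it concerns a different group at a different place on the same ring, and it was within the scatter. With nothing pointing beyond the scatter, compound 3 is expected to show a step of a number 2.8 percentage points lower from compound 2 to compound 3 (within the scatter) in this assay, that is, no change beyond the scatter. The estimate for compound 3 is 23%, with a range from 8% to 40%.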

Compound 3, a percentage reported as inhibition, at one concentration (the size of the read-out at that concentration, not a potency): 29.3%
Beside the measured number, compound 3's estimate is 6.3 percentage points below it; low and high end bracket the measured number.
By their numbers in this assay, from the lowest: compounds 1, 2 and 3 (each within the scatter of the next, the first and the last beyond it).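

In this assay, the change from hydrogen to trifluoromethyl gives a number 3.5 percentage points higher from compound 2 to compound 3 (within the scatter), so this measurement cannot tell the two compounds apart. The aromatic carbon meta to a large group therefore carries trifluoromethyl with no change beyond the scatter, something the earlier step, which concerned a nitro group, could not show. Nothing available explains this result.

As far as these compounds go, whether an amine or a carboxylic acid on this same carbon would shift the number beyond the scatter remains open. From the compounds shown here alone, it is also open whether trifluoromethyl would give the same outcome on the other carbons of this ring, so the finding applies only to this one change at this one position.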